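Triazolylmethyl esters of a hydroxylated triterpenoid core: three limits

The compounds below may be only part of what the source reports. "The series", "measured", "known", "first", "only" and "open" are said of these compounds alone.

Compound 1 `C/C(=C\CC/C(C)=C/CC[C@@H]1[C@@]2(C)CCC(=O)C(C)(C)[C@H]2CC[C@@]1(C)O)CC/C=C(\C)C(=O)OCc1cn(-c2ccc(C(F)(F)F)cc2)nn1` gives > 150000 nM in a functional assay on A549 cells (Homo sapiens) for antiproliferative activity, read by MTT assay, with a stated time of 48 h; a lower number here means a stronger inhibitor, a higher number a weaker inhibitor.
Compound 2 `COc1cccc(-n2cc(COC(=O)/C(C)=C/CC/C(C)=C/CC/C(C)=C/CC[C@@H]3[C@@]4(C)CCC(=O)C(C)(C)[C@H]4CC[C@@]3(C)O)nn2)c1` gives > 150000 nM in this assay.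
Compound 3 `C/C(=C\CC/C(C)=C/CC[C@@H]1[C@@]2(C)CCC(=O)C(C)(C)[C@H]2CC[C@@]1(C)O)CC/C=C(\C)C(=O)OCc1cn(-c2ccccc2[N+](=O)[O-])nn1` gives > 150000 nM in this assay.

Each of these values is a limit of this assay, not a number, so compound 3 stands at the same limit as the other two and cannot be placed relative to them. The three steps between the measured compounds, a step that the two limits leave unreadable from compound 1 to compound 2, a step that the two limits leave unreadable from compound 1 to compound 3 and a step that the two limits leave unreadable from compound 2 to compound 3, are all unreadable for the same reason; what unites them is the limit of > 150000 nM in this assay, at which 3 of the 3 values shown sit.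

Compound 4 `COc1ccccc1-n1cc(COC(=O)/C(C)=C/CC/C(C)=C/CC/C(C)=C/CC[C@@H]2[C@@]3(C)CCC(=O)C(C)(C)[C@H]3CC[C@@]2(C)O)nn1` differs from compound 3 by methoxy in place of nitro on an aromatic carbon; read one bond further out, the change is 2-nitrophenyl to 2-methoxyphenyl. The measured steps that bear on it all concern the aryl group on the triazole nitrogen, and none of them yielded a readable size. There is thus no basis for expecting compound 4 to leave the limit: the expected step that the limit leaves unreadable from compound 3 to compound 4 is essentially none. Compound 4 is therefore estimated at 200000 nM in this assay, with a range from 100000 nM to 500000 nM, most likely reported again as a limit.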

Compound 4, half-maximal inhibitory concentration: > 150000 nM
Compound 4: no number, only a limit; the forecaster's own chance of this, stated with the estimate: 85%; the middle value is on the limit's open side.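

Among these compounds, compound 4 also gives only a limit, not a number, so no step to it from compound 1, compound 2 or compound 3 can be read: the limit of > 150000 nM in this assay, at which 4 of the 4 values shown sit. The compounds shown leave open how far any of these aryl groups on the triazole nitrogen affects activity in this assay, since none gives a value inside the readable range.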